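The source may hold more compounds than are shown below. What is called first, only, known or untested is meant among the compounds shown, and "the series" means these compounds.

Among the compounds with values here, in a functional assay on FM3A cells (Mus musculus) for antiproliferative activity (on this read-out lower numbers stand for stronger inhibition and higher numbers for weaker inhibition), compound 3 `COc1cc(C(=O)c2sc(-c3ccc(F)cc3)cc2N)cc(OC)c1OC` gives 16 nM as the lowest number so far. Compound 2 `COc1cc(C(=O)c2sc(-c3ccncc3)cc2N)cc(OC)c1OC` gives 150 nM on the same read-out. Compound 1 `COc1cc(C(=O)c2sc(-c3ccc(-c4ccccc4)cc3)cc2N)cc(OC)c1OC` stands at > 10000 nM as a limit of the assay, not a number. Compound 4 `COc1ccc(-c2cc(N)c(C(=O)c3cc(OC)c(OC)c(OC)c3)s2)cc1` is still unmeasured and differs from compound 3 by methoxy in place of fluoro on an aromatic carbon, para to a large group methoxy in place of fluoro on an aromatic carbon in its structure.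

Within the data shown here, two measured steps bear on this change. Methoxy brings no ring, unlike the phenyl of compound 1, so the large step of an at least 620-fold lower number from compound 1 to compound 3 (2.79 log units; beyond the scatter) is a poor guide here. The closer guide is the modest step of a 9.4-fold lower number from compound 2 to compound 3 (0.97 log units; beyond the scatter) in which 4-fluorophenyl replaces pyridin-4-yl. The present swap, 4-fluorophenyl to 4-methoxyphenyl, keeps the ring in place, so the expected move in this assay is a small one toward a higher number, an estimated 1.6-fold higher number from compound 3 to compound 4 (0.19 log units; within the scatter) that may stay within the scatter. For compound 4 the estimated value is 25 nM with an expected range from 7 nM to 90 nM.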

Compound 4, half-maximal inhibitory concentration: 31 nM
Compound 4: the middle estimate sits 1.2-fold (0.09 log units) below what was measured, within the range that was stated.
By their numbers in this assay, from the lowest: compounds 3 and 4 (each within the scatter of the next); then compound 2. At a limit, above all of these: compound 1.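

In this assay, methoxy can stand in place of fluoro on the aromatic carbon para to a large group without a change beyond the scatter (a 1.9-fold higher number from compound 3 to compound 4 (0.29 log units; within the scatter)), so this position accepts a group of 2 heavy atoms as well as one of 1. The 4-methoxyphenyl ring also keeps a clear lead over pyridin-4-yl (a 4.8-fold lower number from compound 2 to compound 4 (0.68 log units; beyond the scatter)), which shows that the earlier lead of 4-fluorophenyl was not unique to fluoro. Methoxy in place of phenyl gives a large step (an at least 320-fold lower number from compound 1 to compound 4 (2.50 log units; beyond the scatter)), whose size is only a bound set by a limit of the assay, not a number: the limit of > 10000 nM in this assay, at which 1 of the 4 values shown sits.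

From the compounds shown here alone, how an amine, a carboxylic acid or a longer chain such as butoxy would read at this position remains open. So does the reading of a plain phenyl ring carrying neither fluoro nor methoxy.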